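The source may hold more compounds than are shown below. What is called first, only, known or untested is meant among the compounds shown, and "the series" means these compounds.

Measured so far:
compound 1, `CCCCCCCCCCc1ccc(-c2noc([C@@H]3CCCN3)n2)cc1`, 21%
compound 2, `CCCCCCCCCCc1ccc(-c2noc(CN3CCNCC3)n2)cc1`, 19%

Both numbers come from an assay on HeLa cells for inhibition of sphingosine-1-phosphate transporter SPNS2 (Mus musculus), read by LC-MS, tested at 2 uM; a higher number here means more inhibition at the concentration tested (going by the name of the read-out), a lower number less inhibition. Compound 2 sits alongside compound 1 in this assay: the step of a number 2 percentage points lower from compound 1 to compound 2 (within the scatter) lies within the scatter, so the two compounds cannot be told apart on these numbers. Compound 3, `CCCCCCCCCCc1ccc(-c2noc([C@@H]3CCC[C@@H](N)C3)n2)cc1`, has not yet been measured. It differs from compound 2 by 3-aminocyclohexyl in place of (piperazin-1-yl)methyl on an aromatic carbon. Among the measured compounds shown here, only one measured step bears on this change, a number 2 percentage points lower from compound 1 to compound 2 (within the scatter), and it shows that swapping one nitrogen-containing group for another at this aromatic carbon left the read-out essentially unchanged. The 3-aminocyclohexyl group is a further variation of the same kind at the same place, so no step beyond the scatter is expected for a number 1 percentage points higher from compound 2 to compound 3 (within the scatter). Compound 3 is therefore estimated at 20% in this assay, with a range from 5% to 40%.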

Compound 3, a percentage reported as inhibition, at one concentration (the size of the read-out at that concentration, not a potency): 13%
For compound 3 the middle estimate is 7 percentage points above the measured one; the range from low to high includes it.
By their numbers in this assay, from the lowest: compounds 3, 2 and 1 (each within the scatter of the next).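

Swapping in 3-aminocyclohexyl, whose six-membered ring is carbon only, gives in this assay a number 6 percentage points lower from compound 2 to compound 3 (within the scatter), and set against the five-membered ring of the first compound it gives a number 8 percentage points lower from compound 1 to compound 3 (within the scatter). So a third amine-bearing group, this one with 2 defined stereocentres, can sit on this aromatic carbon without a step beyond the scatter, and the three compounds cannot be put in order on these numbers. Nothing available offers an explanation for these small differences.

The compounds shown leave open whether a group with no amine at this place, such as a carboxylic acid or a plain cyclohexyl, would move the read-out beyond the scatter. They also leave open what the other stereoisomers of 3-aminocyclohexyl would give.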